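Swapping trifluoromethyl for methyl in a growth inhibition series

The source may report more compounds than this note shows. Statements on the series, on what has been measured and on what is new or still open speak of the compounds shown alone.

Values measured in a functional assay on OVCAR-5 cells (Homo sapiens) for inhibition (a higher number here means a weaker inhibitor of growth, a lower number a stronger inhibitor of growth), are as follows
compound 1 `Cc1cc(-c2nc3c(F)cccc3s2)ccc1N` gives 1700 nM
compound 2 `Cc1cc(-c2nc3cccc(F)c3s2)ccc1N` gives 1300 nM
compound 3 `Nc1ccc(-c2nc3ccccc3s2)cc1C(F)(F)F` gives 17400 nM

Compound 3 has the highest number of the three and is the weakest inhibitor, and its gaps to compound 1 and compound 2 both lie beyond the scatter. Compound 4 `Cc1cc(-c2nc3ccccc3s2)ccc1N` differs from compound 3 at one place, with methyl in place of trifluoromethyl on an aromatic carbon ortho to an amino group.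

No two measured compounds differ in only one place, so the size of this step has not been shown directly. Still, compound 1 (1700 nM) and compound 2 (1300 nM) both carry the methyl group, though each also has a fluorine on the core. A clear fall in this assay beyond the scatter is therefore expected. The expected change is a 25-fold lower number from compound 3 to compound 4 (1.40 log units; beyond the scatter) in this estimate. For compound 4 the estimated value is 700 nM with an expected range from 60 nM to 3000 nM in this assay.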

Compound 4, concentration for 50% growth inhibition: 1900 nM
Beside the measured number, compound 4's estimate is 2.7-fold (0.43 log units) below it, and the stated range covers the measured number.
By their numbers in this assay, from the lowest: compounds 2, 1 and 4 (each within the scatter of the next); then compound 3.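

In this assay the exchange of trifluoromethyl for methyl on this aromatic carbon, ortho to an amino group, now has a direct measure in a 9.2-fold lower number from compound 3 to compound 4 (0.96 log units; beyond the scatter) and this places the weak value of compound 3 with the trifluoromethyl group at this position. With methyl held in place, hydrogen in place of fluoro on an aromatic carbon of the shared core gives a 1.5-fold higher number from compound 2 to compound 4 (0.16 log units; within the scatter) and a 1.1-fold higher number from compound 1 to compound 4 (0.05 log units; within the scatter) so neither fluorine placement separates from compound 4 in this read-out. Nothing available here accounts for the size of the trifluoromethyl step.

Going by these compounds, it remains open how hydrogen, chloro, methoxy or an ethyl chain would behave on this same carbon. Also open, on these data alone, is whether a fluorine on the core would matter with trifluoromethyl present.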